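The compounds below may be only part of what the source reports. "The series", "measured", "known", "first", "only" and "open" are said of these compounds alone.

The series shares one core; compound 1 `O=[N+]([O-])c1ccc2[nH]c(Cc3ccc(Oc4ccccc4)cc3)nc2c1` carries a nitro group on an aromatic carbon of it, and in an assay on membranes from brain for binding affinity to Adrenergic receptor alpha-1 (Rattus norvegicus) (on this read-out higher numbers stand for weaker inhibition and lower numbers for stronger inhibition), compound 1 gives 1200 nM. Compound 2 `CCCS(=O)(=O)Nc1ccc2[nH]c(Cc3ccc(Oc4ccccc4)cc3)nc2c1` carries a (propylsulfonyl)amino group in place of that nitro, and in this assay compound 2 gives 4800 nM. For the measured compounds named here, the single measured step, a 4.0-fold higher number from compound 1 to compound 2 (0.60 log units; beyond the scatter), is all that the numbers show so far. Compound 2 thus stands at the higher of the two numbers, with compound 1 as its nearest neighbour at the lower end.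

Compound 3 `O=S(=O)(Nc1ccc2[nH]c(Cc3ccc(Oc4ccccc4)cc3)nc2c1)c1ccccc1` is yet to be measured in this assay. It differs from compound 2 in one place: phenyl in place of propyl on a sulfonyl sulfur. Going by the values given here, no measured step touches the group on the sulfonyl sulfur; the one measured step, a 4.0-fold higher number from compound 1 to compound 2 (0.60 log units; beyond the scatter), exchanges the whole substituent on the aromatic carbon and so gives no guidance on exchanging propyl for phenyl within the sulfonamide. With nothing pointing either way, the expected step of a 1.2-fold lower number from compound 2 to compound 3 (0.08 log units; within the scatter) is set within the scatter, in no particular direction. For compound 3 the estimate in this assay is 4000 nM, with a range from 1000 nM to 16000 nM.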

Compound 3, half-maximal inhibitory concentration: 14000 nM
Compound 3: the middle estimate sits 3.5-fold (0.54 log units) below what was measured; low and high end bracket the measured number.
By their numbers in this assay, from the lowest: compound 1; then compound 2; then compound 3.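

Phenyl in place of propyl on the sulfonyl sulfur gives a 2.9-fold higher number from compound 2 to compound 3 (0.46 log units; beyond the scatter) in this assay. The two sulfonamides therefore do not read alike as replacements for nitro. Measured against nitro on the aromatic carbon, (phenylsulfonyl)amino gives the large step of a 12-fold higher number from compound 1 to compound 3 (1.07 log units; beyond the scatter), whereas (propylsulfonyl)amino gave the modest step of a 4.0-fold higher number from compound 1 to compound 2 (0.60 log units; beyond the scatter); both sulfonamides therefore read higher than the nitro compound, and neither goes against that order. Nothing available here accounts for either step.

The compounds shown leave open whether the higher number follows the aromatic ring itself or simply the size of the group, a question that a longer chain such as butyl or hexyl on the sulfonyl sulfur would help to separate from phenyl. Also open, on these data alone, is whether any other group on this aromatic carbon, such as an amine or a carboxylic acid, would read lower than nitro on this receptor.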